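Cyclohexyl in place of cyclopentyl: what to expect

The source may report more compounds than this note shows. Statements on the series, on what has been measured and on what is new or still open speak of the compounds shown alone.

For the measured compounds named here, in an ADME assay on microsomes (Rattus norvegicus) for metabolic stability (on this read-out higher numbers stand for a longer-lived compound and lower numbers for a shorter-lived compound), compound 1 `O=C(C1CCCC1)N1N=CCC1c1ccccc1` gives 0.2 h, the lower of the two numbers available so far. Going by the values given here, the only other measured compound, compound 2 `O=C(C1CCN(C(=O)C(F)(F)F)CC1)N1N=CCC1c1ccccc1`, gives 0.483 h, and this gap lies beyond the usual scatter of repeated measurements. Compound 2 differs from compound 1 in more than one place, so it is only a loose guide to a single small swap.

The next compound to be measured is compound 3 `O=C(C1CCCCC1)N1N=CCC1c1ccccc1`. It carries cyclohexyl in place of cyclopentyl on a carbonyl carbon, and the rest of the molecule stays the same: cyclohexyl in place of cyclopentyl on a carbonyl carbon. Both groups are non-aromatic rings of carbon only, with no net charge. Among the compounds with values here, no measured pair shows this swap on its own, so the data offer no direct evidence for its effect. In this assay, the expected step of no change at the digits printed from compound 1 to compound 3 (within the scatter) stays within the scatter and has no clear direction. For compound 3 the estimated half-life is 0.2 h, with an expected range from 0.09 h to 0.42 h.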

Compound 3, half-life: 0.0833 h
Compound 3: the middle estimate sits 2.4-fold (0.38 log units) above what was measured; the measured number lies below the stated range.
By their numbers in this assay, from the lowest: compound 3; then compound 1; then compound 2.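

Taken on its own, cyclohexyl in place of cyclopentyl on a carbonyl carbon gives a 2.4-fold lower number from compound 1 to compound 3 (0.38 log units; beyond the scatter) in this assay, a modest step but one beyond the usual scatter. This position is therefore not indifferent to the size of the ring: the half-life responds even though both groups are non-aromatic rings of carbon only, with no hydrogen-bond donors or acceptors and no net charge, and the rest of the molecule stays the same. Among these two compounds, the six-membered ring goes with the shorter-lived compound, and nothing measured so far on this pair explains the step.

A single step gives only one direction at this position, so it cannot show whether the half-life would keep changing with ring size, as it might with cyclobutyl or cycloheptyl in the same place. Also open, on these data alone, is how the number would respond to a different kind of group there, such as a tetrahydropyranyl ring, which brings in an oxygen atom, or an open chain such as isopropyl.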